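Swapping the chlorine position in a pyridine-linked phenol series

The source may report more compounds than this note shows. Statements on the series, on what has been measured and on what is new or still open speak of the compounds shown alone.

Four compounds share a common core carrying a hydroxyphenyl group, and they were examined in an ADME assay on HEK293 cells (Homo sapiens) for cytotoxicity, read by CCK-8 assay and cell counting, with a stated time of 2 days; a higher number here means a weaker inhibitor, a lower number a stronger inhibitor. Compound 1, `Oc1ccc(-c2cc(-c3ccccc3)nc(-c3ccccc3Cl)c2)cc1`, gives 3930 nM. Compound 2, `Oc1ccc(-c2cc(-c3ccncc3)nc(-c3ccccc3Cl)c2)cc1`, gives "not determined" (no result reported) in this assay, so no number is reported for it. Compound 3, `Oc1ccc(-c2cc(-c3ccc(Cl)cc3)nc(-c3ccsc3)c2)cc1`, gives 4860 nM; this number and the number of compound 1 lie within the usual scatter of each other, so neither compound can be said to be a stronger or weaker inhibitor than the other. Compound 4, `Oc1ccc(-c2cc(-c3ccsc3)nc(-c3ccccc3Cl)c2)cc1`, has not yet been measured. It differs from compound 3 by 2-chlorophenyl in place of 4-chlorophenyl on an aromatic carbon, so the two contain the same atoms joined differently. For the measured compounds named here, no measured pair in this set differs at exactly this position, so the size of such a step is unknown here; since the two measured numbers sit so close together, the step from compound 3 to compound 4 is expected to stay within the scatter, as a 1.1-fold lower number from compound 3 to compound 4 (0.03 log units; within the scatter). Compound 4 is therefore estimated at 4500 nM, within a range from 2000 nM to 10000 nM.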

Compound 4, half-maximal inhibitory concentration: 5930 nM
Compound 4: the middle estimate sits 1.3-fold (0.12 log units) below what was measured; the measured number falls inside the stated range.
By their numbers in this assay, from the lowest: compounds 1, 3 and 4 (each within the scatter of the next).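

In this assay, placing the chlorine as 2-chlorophenyl instead of 4-chlorophenyl, on the carbon next to the ring nitrogen, gives a 1.2-fold higher number from compound 3 to compound 4 (0.09 log units; within the scatter), so this shift of one atom around the ring cannot be told apart from repeat measurement. The other comparison concerns thiophen-3-yl in place of phenyl, which gives a 1.5-fold higher number from compound 1 to compound 4 (0.18 log units; within the scatter), and this step also cannot be separated from the scatter. No measurement shown here offers an explanation for these numbers.

All the groups compared at these positions are aromatic rings, and the chlorine has been seen only as part of a phenyl group. Going by these compounds, whether an amine, a carboxylic acid or a longer chain at either position would give a step beyond the scatter remains open.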